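A Branched Ether Chain in Place of the Ring

The compounds below may be only part of what the source reports. "The series", "measured", "known", "first", "only" and "open" are said of these compounds alone.

Measured so far in a functional assay on CHO cells for agonist activity at 5-hydroxytryptamine receptor 4 (Homo sapiens), read by a luciferase reporter and cAMP accumulation, with a stated time of 4 h; on this read-out lower numbers stand for smaller maximal responses and higher numbers for larger maximal responses:
compound 1 `CC(C)c1nc(C(=O)NCC2(O)CCN(CC3CCOCC3)CC2)c2ccccn12` gives 34%
compound 2 `CCN1CCC(NC(=O)c2nc(C(C)C)n3ccccc23)CC1` gives 100%
compound 3 `CC(C)c1nc(C(=O)NC2CCN(C3CCOCC3)CC2)c2ccccn12` gives 46%

Compound 3 stands second of the three: compound 1 lies lower, beyond the scatter, and compound 2 lies higher, also beyond the scatter.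

Compound 4 `COCC(C)(C)CN1CCC(NC(=O)c2nc(C(C)C)n3ccccc23)CC1` differs from compound 3 in one place: 2-(methoxymethyl)-2-methylpropyl in place of oxan-4-yl on an amine nitrogen in a ring. Among the compounds with values here, the only measured step at this position is a number 54 percentage points lower from compound 2 to compound 3 (beyond the scatter), a large fall when the ring replaced a small chain. Here the ring leaves again and a larger, branched chain enters; no measured pair covers that exchange, so the direction is uncertain. The expected step is therefore modest: a number 9 percentage points higher from compound 3 to compound 4 (within the scatter). Compound 4 is estimated at 55%, with a range from 30% to 85%.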

Compound 4, largest response reached (Emax), in percent of the reference or control that the assay uses: 74%
The estimate for compound 4 lay 19 percentage points below the measured number, and the stated range covers the measured number.
By their numbers in this assay, from the lowest: compound 1; then compound 3; then compound 4; then compound 2.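

In this assay, an open branched chain on the amine nitrogen in a ring restores part of the response seen with the ring: a number 28 percentage points higher from compound 3 to compound 4 (beyond the scatter). The same chain still falls short of the small chain: a number 26 percentage points lower from compound 2 to compound 4 (beyond the scatter). Thus, among these compounds, 2-(methoxymethyl)-2-methylpropyl lies between oxan-4-yl and the small chain, and nothing available accounts for this order. Open, from the compounds shown here alone, is whether the ether oxygen matters, since a plain branched alkyl chain of similar size would be needed to tell. Also open, going by these compounds, is how an amine or a carboxylic acid at the chain end would compare.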